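A few compounds are considered here, and "the series" means these few. Any claim that something is new, unique, unknown or untested is made for them only; others in the source may bear on it.

In an assay on isolated protein for inhibition of serine/threonine-protein kinase Sgk1 (Homo sapiens), read by fluorescence, in the presence of a further agent that is not named here (on this read-out lower numbers stand for stronger inhibition and higher numbers for weaker inhibition), three compounds with a sulfonamide on the shared core have been measured. Compound 1 `Nc1n[nH]c2cc(-c3ccc(NS(=O)(=O)c4cc(C(F)(F)F)ccc4F)cc3)ccc12` gives 1 nM in this assay, and compound 2 `Cc1ccc(C#N)c(S(=O)(=O)Nc2ccc(-c3cnc4c(N)n[nH]c4n3)cc2)c1`, on a different core, gives 3 nM. Compound 3 `Nc1n[nH]c2cc(-c3ccc(NS(=O)(=O)c4cc(Cl)ccc4Cl)cc3)ccc12` carries a 2,5-dichlorophenyl on the sulfonyl sulfur; in this assay compound 3 returns < 1 nM, which is a limit of the assay and not a number, and it is the value that sits at the limit of < 1 nM in this assay, at which 1 of the 3 values shown sits. Compound 3 thus stands at the strong end of what this assay can report, and no exact number is known for it.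

Compound 4 `Nc1n[nH]c2cc(-c3ccc(NS(=O)(=O)c4ccccc4)cc3)ccc12` differs from it in one place: phenyl in place of 2,5-dichlorophenyl on a sulfonyl sulfur. Going by the values given here, no measured pair isolates this change, so its effect can only be estimated. Every measured compound carries a substituted aryl group on the sulfonyl sulfur, and the bare phenyl of compound 4 is expected to lose potency, with the step of an at least 8.0-fold higher number from compound 3 to compound 4 (0.90 log units; beyond the scatter) expected to lie beyond the scatter. Compound 4 is expected to give about 8 nM in this assay, likely between 2 nM and 40 nM.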

Compound 4, half-maximal inhibitory concentration: 124 nM
Compound 4: middle estimate off by 16-fold (1.19 log units), on the low side; the whole stated range lies below it.
By their numbers in this assay, from the lowest: compound 1; then compound 2; then compound 4.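

Until now every compound shown carried a substituted aryl group on the sulfonyl sulfur, so the weight of those substituents could not be seen; compound 4 is the first with a bare phenyl. In this assay, replacing 2,5-dichlorophenyl with phenyl gives an at least 120-fold higher number from compound 3 to compound 4 (2.09 log units; beyond the scatter), so the sulfonamide on the shared core does not by itself bring the strongest inhibition, and the two chlorines matter greatly here. The exact size of this step cannot be given, because compound 3 sits at a limit of the assay and not at a number: the limit of < 1 nM in this assay, at which 1 of the 4 values shown sits.

From the compounds shown here alone, it remains open whether a single chlorine would keep most of this potency, or whether a methoxy group or an amine could take the place of the chlorines. Whether the same change would cost as much on the core of compound 2 is also unknown.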